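The source may hold more compounds than are shown below. What is called first, only, known or untested is meant among the compounds shown, and "the series" means these compounds.

Of the compounds shown here, two that share one core have been tested in a functional assay on UACC-62 cells (Homo sapiens) for inhibition, read by sulforhodamine B assay, with a stated time of 48 h, tested at 10 uM; a lower number here means a stronger effect, a higher number a weaker effect of the compound at the concentration tested. Compound 1, `COc1cc2cc(Oc3ccc(NC(=O)Nc4ccccc4)cc3)c(C)nc2cc1OC`, gives 88.4% in this assay. Compound 2, `COc1cc2cc(Oc3ccc(NC(=O)Nc4ccc(C)cc4)cc3)c(C)nc2cc1OC`, gives 99.3% in this assay. Among the compounds with values here, of these two numbers compound 2 stands highest, and the single step that joins them, a number 10.9 percentage points higher from compound 1 to compound 2 (beyond the scatter), is the only one known here. Compound 3, `COc1cc2cc(Oc3ccc(NC(=O)Nc4ccc(C(F)(F)F)cc4)cc3)c(C)nc2cc1OC`, has not yet been measured in this assay. It differs from compound 2 in one place: trifluoromethyl in place of methyl on an aromatic carbon. Within the data shown here, the one measured step put methyl in place of hydrogen on an aromatic carbon, not trifluoromethyl in place of methyl, and it was modest; it bears on the present change only loosely. The number for compound 2 already lies close to the top of what this read-out can show, which leaves little room upward. The step expected in this assay is a number 5.3 percentage points lower from compound 2 to compound 3 (within the scatter), which is to say no move beyond the scatter can be expected with confidence. Compound 3 is therefore estimated at 94%, in a range from 78% to 106%.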

Compound 3, a percentage reported as activity, at one concentration (the size of the read-out at that concentration, not a potency): 69.3%
Estimate against measurement, compound 3: 24.7 percentage points above, outside the stated range (below it).
By their numbers in this assay, from the lowest: compound 3; then compound 1; then compound 2.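

The aromatic carbon para to a large group is not indifferent to what it carries in this assay: replacing methyl with trifluoromethyl there gives a number 30 percentage points lower from compound 2 to compound 3 (beyond the scatter) and marks the largest step among these compounds, while replacing hydrogen with trifluoromethyl gives a number 19.1 percentage points lower from compound 1 to compound 3 (beyond the scatter) and shows that the new group does more than undo the methyl change. Methyl and trifluoromethyl therefore move the number in opposite directions from the hydrogen of compound 1, since the methyl change gave a number 10.9 percentage points higher from compound 1 to compound 2 (beyond the scatter) and only trifluoromethyl brings a stronger effect than hydrogen at this carbon. Nothing available explains why these two groups part ways at this carbon.

Going by these compounds, whether a fluorine atom, a nitrile, a methoxy group or an amine on the same carbon would also lower the number remains open, so three groups cannot yet be read as a trend. On these data alone, compound 3 gives 69.3% at a single concentration, which is a size of effect and not a potency, so how strong it would prove across a range of concentrations also remains open.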